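Bromo Replaces ((Ethoxycarbonyl)carbonyl)amino on the Aromatic Carbon

A few compounds are considered here, and "the series" means these few. Any claim that something is new, unique, unknown or untested is made for them only; others in the source may bear on it.

Measured compounds:
compound 1, `C/N=C(\S)n1nc(-c2ccc(C#N)cc2)nc1N`: 87%
compound 2, `CCOC(=O)C(=O)Nc1ccc(-c2nc(N)n(/C(S)=N/C)n2)cc1`: 49%

Both were tested in a functional assay on the whole organism for inhibition, with Rattus norvegicus as the target, at a dose of 30 mg/kg; a lower number here means less inhibition, a higher number more inhibition at the dose given (going by the name of the read-out). Compound 2 stands lowest of the two numbers; its nearest neighbour is compound 1, and the step of a number 38 percentage points lower from compound 1 to compound 2 (beyond the scatter) separates them, beyond the scatter.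

Compound 3, `C/N=C(\S)n1nc(-c2ccc(Br)cc2)nc1N`, has not yet been tested. It differs from compound 2 by bromo in place of ((ethoxycarbonyl)carbonyl)amino on an aromatic carbon. Going by the values given here, only one measured step bears on this change: in the step from compound 1 to compound 2 the ((ethoxycarbonyl)carbonyl)amino group entered in place of cyano and inhibition fell by a large amount. The change from compound 2 to compound 3 removes that same group again and places a single bromine atom where it stood, a small substituent as cyano was. Because a number 38 percentage points lower from compound 1 to compound 2 (beyond the scatter) was large, a sizeable rise is expected when the group leaves. For compound 3 the inhibition is therefore estimated at 75%, within a range of 50% to 95%. This corresponds to an expected step of a number 26 percentage points higher from compound 2 to compound 3 (beyond the scatter). Bromo is not cyano, so whether compound 3 reaches the level of compound 1 remains open.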

Compound 3, a percentage reported as inhibition, in the whole organism at one dose (the size of the read-out at that dose, not a potency): 88%
For compound 3 the middle estimate is 13 percentage points below the measured one, and the stated range covers the measured number.
By their numbers in this assay, from the lowest: compound 2; then compounds 1 and 3 (each within the scatter of the next).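

Replacing the ((ethoxycarbonyl)carbonyl)amino group with bromo on the aromatic carbon gives a number 39 percentage points higher from compound 2 to compound 3 (beyond the scatter) in this assay, so the fall seen on introducing that group, a number 38 percentage points lower from compound 1 to compound 2 (beyond the scatter), is not tied to the loss of cyano alone and is reversed by a second, different replacement. Bromo in place of cyano gives a number 1 percentage points higher from compound 1 to compound 3 (within the scatter), so the two substituents cannot be told apart at this position in this read-out, and of the three compounds shown only compound 2 stands apart. Nothing available explains why the larger group goes with less inhibition or why bromo and cyano give matching numbers.

The compounds shown leave open whether an amine, a carboxylic acid or a plain acetamide at this position would group with compound 1 and compound 3 or with compound 2, and so which part of the ((ethoxycarbonyl)carbonyl)amino group goes with the lower number. They also leave open whether compound 1 and compound 3 would separate at a lower dose, as this read-out gives the size of the effect at one dose and not a potency.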